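Chloro-to-fluoro exchange: working notes on four compounds

This account rests on a few compounds, and the source may have more. Where it says the series, first, only, none or still open, it means among the compounds named here.

Measured compounds, with values from a functional assay on SK-OV-3 cells (Homo sapiens) for cytotoxicity, read by MTT assay; on this read-out higher numbers stand for weaker inhibition and lower numbers for stronger inhibition:

compound 1 `CC(C)(C)Nc1c(C#N)c(F)c2c(N)nc(N)nc2c1Cl` gives 2.1 ug/mL
compound 2 `CC(C)(C)Nc1c(C#N)c(F)c2c(N)nc(N)nc2c1F` gives 2.4 ug/mL
compound 3 `CCCCNc1c(C#N)c(NCCCC)c2c(N)nc(N)nc2c1Cl` gives 0.6 ug/mL

Compound 2 differs from compound 1 by fluoro in place of chloro on an aromatic carbon, and the step is a 1.1-fold higher number from compound 1 to compound 2 (0.06 log units; within the scatter). Compound 3 has a different core from compound 1; the difference between the two cores is not broken down here. Compound 3 shows the lowest number of the three, and its steps to compound 1 and to compound 2 are both beyond the scatter.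

Compound 4 `CCCCNc1c(C#N)c(NCCCC)c2c(N)nc(N)nc2c1F` is not yet measured. It differs from compound 3 by fluoro in place of chloro on an aromatic carbon. This is the same kind of change as that from compound 1 to compound 2, not the same one: in compound 1 the exchanged carbon is ortho to a (tert-butyl)amino group and para to a fluoro group, whereas in compound 3 it is ortho to a butylamino group and para to a butylamino group. For compound 4 the step expected in this assay is a 1.1-fold higher number from compound 3 to compound 4 (0.03 log units; within the scatter). Among the measured compounds shown here, this rests on the one earlier instance of the exchange, a 1.1-fold higher number from compound 1 to compound 2 (0.06 log units; within the scatter), which stayed within the scatter. Compound 4 is thus expected to give about 0.65 ug/mL, most likely between 0.3 ug/mL and 1.4 ug/mL.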

Compound 4, half-maximal inhibitory concentration: 1.6 ug/mL
Compound 4: middle estimate off by 2.5-fold (0.39 log units), on the low side, outside the stated range (above it).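

In this assay the exchange of chloro for fluoro gives a 2.7-fold higher number from compound 3 to compound 4 (0.43 log units; beyond the scatter) and so lies beyond the scatter on this core, while the earlier instance, a 1.1-fold higher number from compound 1 to compound 2 (0.06 log units; within the scatter), stayed within it. Set side by side, the two steps cannot be told apart on the present numbers: the same change on two cores in this assay, a 1.1-fold higher number (0.06 log units; within the scatter) from compound 1 to compound 2 and a 2.7-fold higher number (0.43 log units; beyond the scatter) from compound 3 to compound 4, 2.3-fold (0.37 log units) apart, within the scatter of two such steps. Among the compounds shown here, the series therefore gives no firm sign that the outcome of this exchange depends on the core, but it does not show that the step carries over unchanged either, since each core offers only a single instance and one step crosses the scatter while the other does not.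

The compounds shown leave open how bromo or a plain hydrogen on the same aromatic carbon would compare with chloro and fluoro on either core. Also open, from the compounds shown here alone, is whether the step would hold with a longer chain in place of the butylamino groups, or with a cyclic amine in place of the (tert-butyl)amino group.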